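The compounds below may be only part of what the source reports. "The series", "measured", "known", "first", "only" and "open" are said of these compounds alone.

Measured so far:
compound 1 `Nc1cc(N)c2nc(-c3ccccc3)c(Sc3ccc(Cl)c(Cl)c3)nc2c1` — < 100000 nM
compound 2 `Nc1cc(N)c2nc(-c3ccccc3)c(Oc3ccc(F)cc3)nc2c1` — < 100000 nM

In a functional assay on KM12 cells (Homo sapiens) for inhibition, read by sulforhodamine B assay, with a stated time of 48 h (a higher number here means that more compound is tolerated, a lower number that less compound is tolerated), compound 1 gives only a limit, < 100000 nM. In this assay compound 2 likewise gives only a limit, < 100000 nM. Compound 2 therefore has no defined place on the numbers shown: its own value is a limit, and the one further value is a limit as well, as the limit of < 100000 nM in this assay, at which 2 of the 2 values shown sit, records. Among the measured compounds shown here, the single measured step, a step that the two limits leave unreadable from compound 1 to compound 2, is unreadable in both size and direction.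

Compound 3 `Nc1cc(N)c2nc(-c3ccccc3)c(Sc3ccc(F)cc3)nc2c1` differs from compound 2 by (4-fluorophenyl)sulfanyl in place of 4-fluorophenoxy on an aromatic carbon. For the measured compounds named here, the only step that bears on this change is a step that the two limits leave unreadable from compound 1 to compound 2, and it yields no readable size, so no step beyond the scatter can be expected in this assay in either direction. The expected step that the limit leaves unreadable from compound 2 to compound 3 is accordingly set at no change. Compound 3 is estimated at 30000 nM, with a range from 5000 nM to 100000 nM, and a further limit rather than a number is the likelier outcome.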

Compound 3, concentration lethal to 50% of the cells: < 100000 nM
Compound 3: a limit, no number; the forecaster's own chance of this, stated with the estimate: 65%; the middle value does not contradict the limit.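

Compound 3, like compound 1 and compound 2, gives only a limit and no number, so no step among these three compounds can be read: the limit of < 100000 nM in this assay, at which 3 of the 3 values shown sit.

On these data alone, whether 4-fluorophenoxy, (4-fluorophenyl)sulfanyl and (3,4-dichlorophenyl)sulfanyl on the shared core differ at all in this assay remains open, in both size and direction.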